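The compounds below may be only part of what the source reports. "The series", "measured", "known", "first", "only" and "open" are said of these compounds alone.

Of the compounds shown here, three built on one shared core have been measured in a functional assay on PC-3 cells (Homo sapiens) for inhibition; on this read-out lower numbers stand for stronger inhibition and higher numbers for weaker inhibition. Compound 1 `COc1cc2nc(N3CCN(C(=O)c4cccc5ccccc45)CC3)nc(N)c2cc1OC` gives 59000 nM. Compound 2 `COc1cc2nc(N3CCN(C(=O)c4ccc(C(C)(C)C)cc4)CC3)nc(N)c2cc1OC` gives 47000 nM in this assay. For the measured compounds named here, the only one-place step among the measured compounds, a 1.3-fold lower number from compound 1 to compound 2 (0.10 log units; within the scatter), concerns a group on a carbonyl carbon. Compound 3 `COc1cc2nc(N3CCN(S(=O)(=O)c4ccc(Cl)s4)CC3)nc(N)c2cc1OC` gives 25000 nM in this assay; its number is the lowest of the three, though the gap to compound 2 lies within the scatter, while the gap to compound 1 lies beyond it.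

Compound 4 `COc1ccc(S(=O)(=O)N2CCN(c3nc(N)c4cc(OC)c(OC)cc4n3)CC2)cc1` is the next compound for this assay. It differs from compound 3 by 4-methoxyphenyl in place of 5-chlorothiophen-2-yl on a sulfonyl sulfur. Going by the values given here, no measured step touches the group on the sulfonyl sulfur: the single step available concerns the carbonyl side and stayed within the scatter, so it gives no lead in either direction. The step expected from compound 3 to compound 4 is therefore a 1.1-fold higher number from compound 3 to compound 4 (0.05 log units; within the scatter), nothing beyond the scatter. Compound 4 is estimated at 28000 nM, with a range from 9000 nM to 90000 nM.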

Compound 4, half-maximal inhibitory concentration: 39000 nM
The estimate for compound 4 lay 1.4-fold (0.14 log units) below the measured number, within the range that was stated.
By their numbers in this assay, from the lowest: compounds 3, 4, 2 and 1 (each within the scatter of the next, the first and the last beyond it).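

In this assay, for the compounds shown here, the step at the sulfonyl sulfur is the first to test this position, and a 1.6-fold higher number from compound 3 to compound 4 (0.19 log units; within the scatter) shows that 4-methoxyphenyl can take the place of 5-chlorothiophen-2-yl without a change that can be told from the scatter. A six-membered carbon ring therefore serves here as well as a five-membered aromatic ring with a hetero atom, and the chlorine of compound 3 is not needed to hold the number at this level. No measured information bears on why the two groups read alike.

On these data alone, whether an amine, a carboxylic acid or a plain methyl on the sulfonyl sulfur would move the number beyond the scatter remains open. Also open, as far as these compounds go, is how a sulfonyl and a carbonyl compare when both carry the same group.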